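Adding a methoxy to a weakly cytotoxic dienone

The source may report more compounds than this note shows. Statements on the series, on what has been measured and on what is new or still open speak of the compounds shown alone.

Three compounds have been measured in an ADME assay on RAW264.7 cells (Mus musculus) for cytotoxicity, read by MTT assay; a higher number here means a weaker inhibitor, a lower number a stronger inhibitor:
Compound 1 `O=C(/C=C/C=C/c1ccccc1)c1ccccc1` gives 44300 nM.
Compound 2 `COc1ccc(/C=C/C=C/C(=O)c2ccccc2)cc1` reaches only the limit of the assay, > 100000 nM.
Compound 3 `CN(C)c1ccc(/C=C/C=C/C(=O)c2ccccc2)cc1` likewise reaches only the limit of the assay, > 100000 nM.

Compound 2 arises from compound 1 by methoxy in place of hydrogen on an aromatic carbon, and an at least 2.2-fold higher number from compound 1 to compound 2 (0.35 log units; beyond the scatter). Compound 3 arises from compound 1 by dimethylamino in place of hydrogen on an aromatic carbon, and an at least 2.2-fold higher number from compound 1 to compound 3 (0.35 log units; beyond the scatter). Between the two limits, a step that the two limits leave unreadable from compound 2 to compound 3. Compound 4 `COc1ccc(C(=O)/C=C/C=C/c2ccc(N(C)C)cc2)cc1` has not been measured yet; it arises from compound 3 by methoxy in place of hydrogen on an aromatic carbon, the same change, in the same place, that made compound 2 from compound 1. In this assay compound 4 is expected to show a step that the limit leaves unreadable from compound 3 to compound 4, resting on compound 3 already sitting at the limit of > 100000 nM in this assay, at which 2 of the 3 values shown sit, and on an at least 2.2-fold higher number from compound 1 to compound 2 (0.35 log units; beyond the scatter). Compound 4 is therefore estimated at 150000 nM, most likely reported again only as a limit.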

Compound 4, half-maximal inhibitory concentration: > 100000 nM
Compound 4 ended at the assay's limit; the forecaster's own chance of this, stated with the estimate: 85%; the middle value is on the limit's open side.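

In this assay, among these compounds, compound 4 gives > 100000 nM as a limit of the assay, and compound 3 also stands at a limit, so no step between them can be read. The compounds shown leave open whether compound 2, compound 3 and compound 4 differ at all in cytotoxicity.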